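The source may report more compounds than this note shows. Statements on the series, on what has been measured and on what is new or still open speak of the compounds shown alone.

Measured so far in a functional assay on HeLa cells (Homo sapiens) for inhibition, read by MTT assay, with a stated time of 24 h; a lower number here means a stronger inhibitor, a higher number a weaker inhibitor:
compound 1, `O=C(O)C1=Cc2ccccc2OC1(OCc1cc(-c2ccc([N+](=O)[O-])cc2)no1)C(F)(F)F`, a limit of the assay only: > 150000 nM
compound 2, `CCOC(=O)C1=Cc2ccccc2OC1(OCc1cn(-c2ccc(F)c([N+](=O)[O-])c2)nn1)C(F)(F)F`, 15600 nM
compound 3, `CCOC(=O)C1=Cc2ccccc2OC1(OCc1cc(-c2ccc([N+](=O)[O-])cc2)no1)C(F)(F)F`, a limit of the assay only: > 150000 nM

Compound 1 stands at the limit and gives no number, and (the limit of > 150000 nM in this assay, at which 2 of the 3 values shown sit). Among the measured compounds shown here, the one step measured in one place, a step that the two limits leave unreadable from compound 1 to compound 3, is unreadable. Compound 4, `O=C(O)C1=Cc2ccccc2OC1(OCc1cc(-c2cccc(C(F)(F)F)c2)no1)C(F)(F)F`, differs from compound 1 by 3-(trifluoromethyl)phenyl in place of 4-nitrophenyl on an aromatic carbon. For the measured compounds named here, no measured step bears on this change; compound 2 differs from compound 1 in the five-membered ring and the ester as well, so its value cannot be set against the aryl change. Compound 4 is expected to stay near the limit, at 150000 nM, from 30000 nM to 500000 nM. This means an expected step of a number no higher from compound 1 to compound 4 (the limit leaves the size open), with a limit the likelier outcome.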

Compound 4, half-maximal inhibitory concentration: > 150000 nM
Compound 4: no number, only a limit (the forecaster's own chance of this, stated with the estimate: 65%); the middle value lies on the limit itself.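

Compound 1 and compound 4 each give only a limit in this assay, so no step can be read between them: the limit of > 150000 nM in this assay, at which 3 of the 4 values shown sit.

The compounds shown leave open how 3-(trifluoromethyl)phenyl and 4-nitrophenyl compare on the shared core.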